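Nitro for Nitrile on Two Different Cores

This account rests on a few compounds, and the source may have more. Where it says the series, first, only, none or still open, it means among the compounds named here.

Compound 1 `CC(O)(COc1cc(C(F)(F)F)cc(C(F)(F)F)c1)C(=O)Nc1ccc(C#N)cc1C(F)(F)F`: 8050 nM in a functional assay on DU-145 cells (Homo sapiens) for antiproliferative activity, read by fluorescence and propidium iodide staining, with a stated time of 96 h; on this read-out lower numbers stand for stronger inhibition and higher numbers for weaker inhibition
Compound 2 `CC(O)(COc1cc(C(F)(F)F)cc(C(F)(F)F)c1)C(=O)Nc1ccc([N+](=O)[O-])cc1C(F)(F)F`: 11600 nM
Compound 3 `CC1(C)C(=O)N(c2ccc(C#N)cc2C(F)(F)F)C(=S)N1c1cc(C(F)(F)F)cc(C(F)(F)F)c1`: "nd(insoluble)" (no result reported), that is, no number reported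
Compound 4 `CC1(C)C(=O)N(c2ccc([N+](=O)[O-])cc2C(F)(F)F)C(=S)N1c1cc(C(F)(F)F)cc(C(F)(F)F)c1`: not yet measured

Compounds 1 and 2 share one core and differ by nitro in place of cyano on an aromatic carbon. That change gave a 1.4-fold higher number from compound 1 to compound 2 (0.16 log units; within the scatter). Compound 3 carries a different core; the difference between the two cores is not broken down here. Compound 4 differs from compound 3 by nitro in place of cyano on an aromatic carbon, the same change as between compounds 1 and 2, at the same place. In this assay a step of similar size, within the scatter, is expected from compound 3 to compound 4, resting on a 1.4-fold higher number from compound 1 to compound 2 (0.16 log units; within the scatter); but compound 3 gave no number, so there is no anchor, and the values of compound 1 and compound 2 remain the only measured points. Compound 4 is expected to give 10000 nM, between 3000 nM and 40000 nM, with a real chance that it too yields no number.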

Compound 4, half-maximal inhibitory concentration: 10000 nM
The estimate for compound 4 equals the measured number at the digits printed; low and high end bracket the measured number.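

Going by these compounds alone, compound 3 gave no number, so no step from it to compound 4 can be read. Still open, as far as these compounds go, is whether nitro in place of cyano acts on the core of compound 3 as it does on the core of compound 1. Nothing shown here offers an explanation for these values.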